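The source may hold more compounds than are shown below. What is called first, only, known or untested is meant among the compounds shown, and "the series" means these compounds.

Measured so far in a physicochemical assay for solubility, in phosphate buffer, at pH 7.4; a lower number here means a less soluble compound, a higher number a more soluble compound:

- compound 1 `OCC1CCN(c2nccnc2OC2CN(c3nc4ccccc4s3)C2)CC1` gives 31000 nM
- compound 2 `OCC1CCN(c2nccnc2OC2CN(c3ncc4ccccc4n3)C2)CC1` gives 174000 nM
- compound 3 `c1ccc2nc(N3CC(Oc4nccnc4N4CCCCC4)C3)ccc2c1` gives < 1000 nM, which is a limit of the assay and not a number

Compound 1 and compound 2 both have real numbers, and they lie well clear of the limit that marks the bottom of the readable range. Among the compounds with values here, compound 3 has no number, and it is the one compound that sits at the limit of < 1000 nM in this assay, at which 1 of the 3 values shown sits.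

Compound 4 `N#Cc1ccc(-c2nccnc2OC2CN(c3ccc4ccccc4n3)C2)cc1` has not been measured. It carries 4-cyanophenyl in place of piperidin-1-yl on an aromatic carbon of a six-membered aromatic ring with 2 nitrogen (4-cyanophenyl in place of piperidin-1-yl on an aromatic carbon). Within the data shown here, no measured pair shows what this exchange does in this assay, so no step beyond the scatter is expected, and no direction can be argued with confidence. Among the measured compounds shown here, the only anchor is compound 3 with < 1000 nM, again a limit. The estimated change is a step that the limit leaves unreadable from compound 3 to compound 4. For compound 4 the expected value is 800 nM, with an estimated range from 250 nM to 3000 nM.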

Compound 4, solubility: < 1000 nM
Compound 4: no number, only a limit; the forecaster's own chance of this, stated with the estimate: 70%; the middle value does not contradict the limit.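

Within the data shown here, compound 3 and compound 4 each give only a limit in this assay and not a number, so no step between them can be read: the limit of < 1000 nM in this assay, at which 2 of the 4 values shown sit.

On these data alone, what 4-cyanophenyl in place of piperidin-1-yl does in this assay stays open, in both direction and size.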